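Dichlorophenyl in Place of Phenyl on the Ring Nitrogen Arm

A few compounds are considered here, and "the series" means these few. Any claim that something is new, unique, unknown or untested is made for them only; others in the source may bear on it.

Compound 1 `CCCCNc1nc(N)nc2c1CN(Cc1ccccc1)CC2` stands lowest of the three measured: in an assay on HEK293 cells for agonist activity at Toll-like receptor 8 (Homo sapiens), read by a luciferase reporter, with a stated time of 6 h (on this read-out higher numbers stand for an effect only at larger amounts of compound and lower numbers for an effect already at smaller amounts), compound 1 gives 0.06 uM. Compound 2 `CCCCNc1nc(N)nc2c1CCN(C)C2` gives 0.2 uM in this assay, and compound 3 `CCCCNc1nc(N)nc2c1CN(C(C)=O)CC2` gives 0.5 uM. For the measured compounds named here, the only single-place step measured, an 8.3-fold higher number from compound 1 to compound 3 (0.92 log units; beyond the scatter), replaces the whole substituent on the ring nitrogen. Compound 4 `CCCCNc1nc(N)nc2c1CN(Cc1cccc(Cl)c1Cl)CC2` keeps that substituent and alters only its aromatic ring: 2,3-dichlorophenyl in place of phenyl on a saturated chain carbon bound to an amine nitrogen in a ring. Going by the values given here, no measured step bears on adding chlorine to this phenyl, so the known step offers little guidance, and a small move in either direction, or none beyond the scatter, is the reasonable expectation. Compound 4 is therefore estimated at 0.05 uM, between 0.02 uM and 0.15 uM, an expected step of a 1.2-fold lower number from compound 1 to compound 4 (0.08 log units; within the scatter).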

Compound 4, minimum effective concentration: 0.18 uM
Compound 4: the middle estimate sits 3.6-fold (0.56 log units) below what was measured; measured number outside the range, above it.
By their numbers in this assay, from the lowest: compound 1; then compounds 4 and 2 (each within the scatter of the next); then compound 3.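

In this assay, 2,3-dichlorophenyl in place of phenyl on a saturated chain carbon bound to an amine nitrogen in a ring gives a 3.0-fold higher number from compound 1 to compound 4 (0.48 log units; beyond the scatter). The number therefore responds to a change on the aromatic ring alone, whereas the earlier step, an 8.3-fold higher number from compound 1 to compound 3 (0.92 log units; beyond the scatter), replaced the whole substituent on the ring nitrogen. Nothing available explains this shift. From the compounds shown here alone, whether one chlorine alone would produce the same step remains open. So does the outcome with a methoxy group on this phenyl, or with a pyridine ring in its place.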